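This account rests on a few compounds, and the source may have more. Where it says the series, first, only, none or still open, it means among the compounds named here.

Three compounds of the shared core have been run in a functional assay for inhibition, with Homo sapiens as the target; on this read-out higher numbers stand for weaker inhibition and lower numbers for stronger inhibition. Compound 1 `Cc1cn(-c2ccc(Nc3nccc(-c4ccncc4)n3)cc2)cn1` is reported only as a limit, > 3000 nM, and so stands at the limit of > 3000 nM in this assay, at which 1 of the 3 values shown sits, rather than at a number. Compound 2 `COc1ccc(Nc2nccc(-c3ccccn3)n2)cc1` gives 8300 nM and compound 3 `Cc1ccc(-c2ccnc(Nc3cccc(N(C)C)c3)n2)s1` gives 5700 nM; these two values lie within the scatter of each other. Compound 4 `CN(C)c1ccc(Nc2nccc(-c3ccncc3)n2)cc1` is not yet measured; it differs from compound 1 by dimethylamino in place of 4-methyl-1H-imidazol-1-yl on an aromatic carbon. Within the data shown here, no step between measured compounds is available, and compound 1 offers only a limit, so no measured change can be attached to this replacement. The expected step in this assay is a step that the limit leaves unreadable from compound 1 to compound 4, which is none beyond the scatter in either direction. Compound 4 is therefore estimated at 5000 nM, with a range from 1500 nM to 15000 nM.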

Compound 4, half-maximal inhibitory concentration: 3700 nM
Estimate against measurement, compound 4: 1.4-fold (0.13 log units) above; the measured number falls inside the stated range.
By their numbers in this assay, from the lowest: compounds 4, 3 and 2 (each within the scatter of the next, the first and the last beyond it).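

No step can be read from compound 1 to compound 4, because compound 1 is reported only as a limit: the limit of > 3000 nM in this assay, at which 1 of the 4 values shown sits. From the compounds shown here alone, whether dimethylamino in place of 4-methyl-1H-imidazol-1-yl shifts inhibition at all stays open.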